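Working notes: from compound 3 to compound 4

The source may hold more compounds than are shown below. What is called first, only, known or untested is meant among the compounds shown, and "the series" means these compounds.

- compound 1 `OC[C@H]1O[C@@H](n2cnc3c(NCc4ccc(Cl)cc4)ncnc32)[C@H](O)[C@@H]1O`: 218000 nM
- compound 2 `OC[C@H]1O[C@@H](n2cnc3c(NCc4ccc(Br)cc4)ncnc32)[C@H](O)[C@@H]1O`: 68200 nM
- compound 3 `COc1cc(CNc2ncnc3c2ncn3[C@@H]2O[C@H](CO)[C@@H](O)[C@H]2O)cc(OC)c1`: > 166000 nM, a limit

In a functional assay on K562 cells (Homo sapiens) for antiproliferative activity, with a stated time of 72 h (on this read-out lower numbers stand for stronger inhibition and higher numbers for weaker inhibition), compound 3 reaches only a limit, > 166000 nM. Compound 4 `OC[C@H]1O[C@@H](n2cnc3c(NCc4ccc(F)c(F)c4F)ncnc32)[C@H](O)[C@@H]1O` carries 2,3,4-trifluorophenyl in place of 3,5-dimethoxyphenyl on a saturated chain carbon bound to a nitrogen on an aromatic ring. The nearest measured steps are an at least 2.4-fold higher number from compound 2 to compound 3 (0.38 log units; beyond the scatter) and a step that the limit leaves unreadable from compound 1 to compound 3, and the halogen exchange gave a 3.2-fold lower number from compound 1 to compound 2 (0.50 log units; beyond the scatter). Compound 2 gives 68200 nM but compound 1 gives 218000 nM, so a halogen alone promises little. The expected step is an at least 1.1-fold lower number from compound 3 to compound 4 (0.04 log units; that floor lies within the scatter), estimated as none beyond the scatter. In this assay the estimated value for compound 4 is 150000 nM, with an expected range of 60000 nM to 350000 nM.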

Compound 4, half-maximal inhibitory concentration: > 166000 nM
Compound 4 ended at the assay's limit (the forecaster's own chance of this, stated with the estimate: 35%); middle value at least 1.1-fold (0.04 log units) from the limit.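

In this assay compound 4 reaches only a limit, > 166000 nM. Replacing 4-bromophenyl with 2,3,4-trifluorophenyl on this saturated chain carbon gives an at least 2.4-fold higher number from compound 2 to compound 4 (0.38 log units; beyond the scatter), while the steps linking compound 4 with compound 1 and compound 3 cannot be read. A fluorinated ring here thus ends at the same limit as the 3,5-dimethoxyphenyl ring: the limit of > 166000 nM in this assay, at which 2 of the 4 values shown sit.

As far as these compounds go, whether an amine or a carboxylic acid on this phenyl ring would bring a readable value remains open. From the compounds shown here alone, the true values of compound 3 and compound 4 also remain unknown.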